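Changing the Carboxyphenyl Ether and the Expected Maximal Response

This account rests on a few compounds, and the source may have more. Where it says the series, first, only, none or still open, it means among the compounds named here.

Measured so far:
compound 1 `Cc1c(OCCCCOc2ccc(C(=O)O)c(Cl)c2)ccc(C(=O)CC(C)C)c1O` gives 80.5%
compound 2 `Cc1c(OCCCCOc2ccc(C(=O)O)cc2)ccc(C(=O)CC2CCCC2)c1O` gives 82.6%
compound 3 `COc1ccc(C(=O)O)cc1OCCCCOc1ccc(C(=O)CC2CCCC2)c(O)c1C` gives 91.8%

All three numbers come from an assay on HEK293 cells for positive allosteric modulation of metabotropic glutamate receptor 2 (Rattus norvegicus), read by thallium flux, with a stated time of 2.5 min; a lower number here means a smaller maximal response, a higher number a larger maximal response. Compound 3 holds the highest number of the three; its gap to compound 2 lies within the usual scatter, and only its gap to compound 1 lies beyond it, so no firm order among the three can be read from these values alone.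

Compound 4 `Cc1c(OCCCCOc2ccc(C(=O)O)c(Cl)c2)ccc(C(=O)CC2CCCC2)c1O` is not yet measured. It follows from compound 3 by the change (4-carboxy-3-chlorophenyl in place of 5-carboxy-2-methoxyphenyl on an oxygen on a saturated carbon). Within the data shown here, one measured step bears on this: a number 9.2 percentage points higher from compound 2 to compound 3 (within the scatter), which brought in the very group that now leaves, and was within the scatter. Compound 4 also shares its 4-carboxy-3-chlorophenyl group with compound 1, whose number is the lowest shown, although the two differ elsewhere as well. Among the measured compounds shown here, the estimated step is therefore a number 9.8 percentage points lower from compound 3 to compound 4 (within the scatter), a step back of about the same size as the one from compound 2 to compound 3. Compound 4 is estimated at 82%, between 70% and 94%.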

Compound 4, largest response reached (reported as percent of maximum), in percent of the reference or control that the assay uses: 80.8%
Beside the measured number, compound 4's estimate is 1.2 percentage points above it; the range from low to high includes it.
By their numbers in this assay, from the lowest: compounds 1, 4, 2 and 3 (each within the scatter of the next, the first and the last beyond it).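

In this assay, the change at this oxygen gives a step beyond the scatter (a number 11 percentage points lower from compound 3 to compound 4 (beyond the scatter)), whereas the earlier step at the same place, which brought in 5-carboxy-2-methoxyphenyl, stayed within it. Chloro in place of hydrogen on an aromatic carbon stays within the scatter (a number 1.8 percentage points lower from compound 2 to compound 4 (within the scatter)), and so does cyclopentyl in place of isopropyl on the saturated chain carbon (a number 0.3 percentage points higher from compound 1 to compound 4 (within the scatter)), so neither change separates its pair of compounds. Nothing available explains the difference between compound 3 and compound 4.

Open, from the compounds shown here alone, is how much of that difference belongs to the methoxy group and how much to the loss of chloro, as the two change together in this step. Also open, going by these compounds, is how the maximal response would move with a fluoro group or an amine on this aromatic ring, or with a tetrazole in place of the carboxylic acid.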